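The source may hold more compounds than are shown below. What is called first, only, known or untested is meant among the compounds shown, and "the series" means these compounds.

Measured compounds:
- compound 1 `COc1cc(C)nc(NC(=S)NC(=O)c2c(-c3ccc(Cl)cc3Cl)noc2C)n1`: 15.3% in a functional assay on the whole organism for inhibition, with Chenopodium ficifolium as the target, with a stated time of 72 h, tested at 10 mg/L; on this read-out lower numbers stand for less inhibition of growth and higher numbers for more inhibition of growth at the one concentration tested
- compound 2 `COc1cc(SC)nc2n/c(=N/C(=O)c3c(-c4ccc(Cl)cc4Cl)noc3C)sn12`: 23.8% in this assay

Compound 1 shows the lower of the two numbers in this assay, but the gap to compound 2 lies within the usual scatter of this read-out, so the two cannot be told apart on these numbers. Among the measured compounds shown here, no step between measured compounds is available for this pair of shared core and differing heteroaryl side.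

The unmeasured compound 3 `COc1cc(OC)nc(NC(=S)NC(=O)c2c(-c3ccc(Cl)cc3Cl)noc2C)n1` differs from compound 1 in one place: methoxy in place of methyl on an aromatic carbon. Nothing in the measured pair speaks to this exchange, so the step is expected to be small. For compound 3 the step of a number 2.7 percentage points higher from compound 1 to compound 3 (within the scatter) in this assay is expected to stay within the scatter, with no clear direction. Compound 3 is therefore estimated at 18% in this assay, with a range from 7% to 32%.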

Compound 3, percent growth inhibition at one concentration: 30.7%
Compound 3: middle estimate off by 12.7 percentage points, on the low side; the range from low to high includes it.
By their numbers in this assay, from the lowest: compounds 1, 2 and 3 (each within the scatter of the next, the first and the last beyond it).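

Going from 4-methoxy-6-methylpyrimidin-2-yl to 4,6-dimethoxypyrimidin-2-yl gives a number 15.4 percentage points higher from compound 1 to compound 3 (beyond the scatter) in this assay, so this place on the aromatic ring, next to the ring nitrogen, does respond to substitution at the one concentration tested. Among the compounds shown here, this is the first step that isolates a single exchange, and it shows that methoxy in place of methyl goes with more inhibition of growth in this pair. No measurement shown bears on the reason for this step.

The compounds shown leave open whether the step is specific to methoxy, since an ethyl group, a chlorine or an amino group at the same place would test that. Also open, as far as these compounds go, is how the series responds when the remaining methoxy group is exchanged, as in a 4,6-dimethylpyrimidin-2-yl analogue.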